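A few compounds are considered here, and "the series" means these few. Any claim that something is new, unique, unknown or untested is made for them only; others in the source may bear on it.

Of the compounds shown here, three have been measured in a physicochemical assay for lipophilicity, measured as octanol-water partition; a higher number here means a more lipophilic compound, a lower number a more polar compound. Compound 1 `CCO/N=C/Nc1cc(Cl)c(S(=O)(=O)CC)c(Cl)c1` gives 2.8, compound 2 `CCO/N=C/Nc1cc(Cl)c(OCC#N)c(Cl)c1` gives 3.1, and compound 3 `C#CCc1c(Cl)cc(N/C=N/OCC=C)cc1Cl` gives 3.7, the highest of the three numbers, beyond the scatter from both of the others. Going by the values given here, the one measured step, a number 0.30 log units higher from compound 1 to compound 2 (within the scatter), lies within the scatter and concerns a change unlike the one at hand. Compound 4 `C#CCc1c(Cl)cc(N/C=N/OCc2ccccc2)cc1Cl` differs from compound 3 in one place: phenyl in place of vinyl on a saturated chain carbon bound to an oxygen. Among the compounds with values here, no measured step covers this change, so the expectation rests on the ring that enters in place of the two-carbon group that leaves; a sizeable rise in this assay is expected, a number 1.10 log units higher from compound 3 to compound 4 (beyond the scatter). For compound 4 the expected value is 4.8, between 4.3 and 5.3.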

Compound 4, partition coefficient: 4.2
For compound 4 the middle estimate is 0.60 log units above the measured one; measured number below the stated range.
By their numbers in this assay, from the lowest: compounds 1 and 2 (each within the scatter of the next); then compound 3; then compound 4.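

In this assay, going by these compounds alone, phenyl in place of vinyl on a saturated chain carbon bound to an oxygen gives a number 0.50 log units higher from compound 3 to compound 4 (beyond the scatter) and so, unlike the one earlier step, lies clearly outside the scatter. Within the data shown here, this is the first reading of any change at this place, and it shows that the number here responds to the swap from the two-carbon group to the ring. Nothing available explains the size of this step. On these data alone, whether a longer chain, an amine or a carboxylic acid at this place would move the number, and in which direction, stays open. So does whether the same swap would give a similar step on another core.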